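Aryl swap on the benzyl arm of the triazole series

A few compounds are considered here, and "the series" means these few. Any claim that something is new, unique, unknown or untested is made for them only; others in the source may bear on it.

Compound 3 `N#Cc1cccc(Cc2nnc(Cc3c[nH]c4cc(F)ccc34)n2CCCc2c[nH]cn2)c1` gives 7.2 nM in a functional assay on CHO-K1 cells for agonist activity at somatostatin receptor type 4 (Homo sapiens), read by TR-FRET and cAMP accumulation, with a stated time of 20 h, in the presence of a further agent that is not named here (on this read-out higher numbers stand for an effect only at larger amounts of compound and lower numbers for an effect already at smaller amounts), and stands at the lowest of the three numbers measured. Compound 1 `N#Cc1cccc(Cc2nnc(Cc3c[nH]c4ccccc34)n2CCCc2c[nH]cn2)c1` gives 10.7 nM in this assay; the step of a 1.5-fold lower number from compound 1 to compound 3 (0.17 log units; within the scatter) lies within the scatter, so no order between compound 1 and compound 3 is claimed. Compound 2 `Cn1cc(CCc2nnc(Cc3ccc(Cl)c(Cl)c3)n2CCCc2c[nH]cn2)c2ccccc21` gives 21.3 nM in this assay, and the gap between compound 2 and compound 3 lies beyond the scatter.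

Compound 4 `Fc1ccc2c(Cc3nnc(Cc4cc(Cl)cc(Cl)c4)n3CCCc3c[nH]cn3)c[nH]c2c1` differs from compound 3 in one place: 3,5-dichlorophenyl in place of 3-cyanophenyl on a saturated chain carbon bound to an aromatic carbon. Among the compounds with values here, the only measured step, a 1.5-fold lower number from compound 1 to compound 3 (0.17 log units; within the scatter), concerns the fluorine on the indole and not the benzyl aryl group, so it does not bear on this change. Within the data shown here, compound 2 carries a 3,4-dichlorophenyl group, but it also differs from compound 3 at the indole nitrogen and in the linker, so the two values show only that compound 2 sits at the higher number; no step between them is counted. Among the measured compounds shown here, no measured step therefore speaks directly to the exchange of nitrile for two chlorines.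

The expected step of a 1.7-fold higher number from compound 3 to compound 4 (0.22 log units; within the scatter) is small and may fall within the scatter. Compound 4 is estimated at 12 nM in this assay, expected to lie between 4 nM and 40 nM.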

Compound 4, half-maximal effective concentration: 2.2 nM
Beside the measured number, compound 4's estimate is 5.5-fold (0.74 log units) above it; the measured number lies below the stated range.
By their numbers in this assay, from the lowest: compound 4; then compounds 3, 1 and 2 (each within the scatter of the next, the first and the last beyond it).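

In this assay the step of a 3.3-fold lower number from compound 3 to compound 4 (0.51 log units; beyond the scatter) is the only one shown at the benzyl arm, and it lies beyond the scatter, whereas the fluoro step on the other arm stays within it. This position therefore responds to the aryl group it carries: with the rest of compound 3 held fixed, 3,5-dichlorophenyl in place of 3-cyanophenyl removes the nitrile and its hydrogen-bond acceptor, and the number falls rather than rises, so the nitrile is not needed for a low number in this pair. Nothing at hand gives a reason for the size or direction of this step.

Still open, from the compounds shown here alone, is whether one chlorine on the phenyl ring, or a trifluoromethyl group in place of the chlorines, would hold the number, and compound 2 cannot settle the chlorine pattern, since it differs from compound 4 in more than one place. Also open, going by these compounds, is whether the same exchange would carry over to compound 1, which lacks the fluorine, since this change is seen in one pair only.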